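A few compounds are considered here, and "the series" means these few. Any claim that something is new, unique, unknown or untested is made for them only; others in the source may bear on it.

Measured so far in an ADME assay on microsomes from liver (Rattus norvegicus) for metabolic stability, read by LC-MS, with a stated time of 10 min, tested at 0.5 uM; a higher number here means that more of the compound is left, a lower number that less of the compound is left:
- compound 1 `c1ccc2c(c1)CN[C@@H](CN(CCC1CCNCC1)[C@H]1CCCc3cccnc31)C2` with 17%
- compound 2 `c1cnc2c(c1)CCC[C@@H]2N(CCCN1CCNCC1)Cc1cc2ccccc2cn1` with 59%
- compound 3 `c1cnc2c(c1)CCC[C@@H]2N(CCCN1CCNCC1)Cc1nc2ccccc2s1` with 21%

Compound 1 and compound 3 lie within the scatter of each other at the low end of these numbers, and compound 2 stands beyond the scatter above both. Compound 4 `c1ccc2c(c1)CN[C@@H](CN(CC[C@H]1CCCNC1)[C@H]1CCCc3cccnc31)C2` keeps the core of compound 1 and changes one group (piperidin-3-yl in place of piperidin-4-yl on a saturated chain carbon, two bonds along the chain from an amine nitrogen) so that the two have the same atoms, joined differently. Cut one bond further out, the difference reads (piperidin-4-yl)methyl to (piperidin-3-yl)methyl.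

Among the compounds with values here, only one measured step is available (a number 38 percentage points lower from compound 2 to compound 3 (beyond the scatter)) and it concerns a different group. It shows that a single swap can move this read-out a long way, but nothing measured covers the piperidine change itself. A small upward step is therefore expected, and the step estimated in this assay is (a number 3 percentage points higher from compound 1 to compound 4 (within the scatter)) with a wide margin on the upper side. For compound 4 the estimated value is 20% with an expected range from 8% to 38% as the measurement is awaited.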

Compound 4, percent of the compound remaining: 55%
Compound 4: the middle estimate sits 35 percentage points below what was measured, and the stated range ends below it.
By their numbers in this assay, from the lowest: compounds 1 and 3 (each within the scatter of the next); then compounds 4 and 2 (each within the scatter of the next).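

In this assay the change from piperidin-4-yl to piperidin-3-yl gives a number 38 percentage points higher from compound 1 to compound 4 (beyond the scatter) and thus counts as a large step between two compounds with the same atoms, joined differently. Within the data shown here, this shows that the read-out depends strongly on where the piperidine ring is attached at this place, on a saturated chain carbon, two bonds along the chain from an amine nitrogen, whereas the one earlier step concerned a different group. Nothing given here accounts for the size of this step.

The compounds shown leave open whether the mirror-image arrangement at the defined stereocentre of the piperidin-3-yl group would give a similar number. They also leave open whether a pyrrolidin-3-yl group or a longer chain in this place would keep the higher number.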